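The source may hold more compounds than are shown below. What is called first, only, known or untested is meant among the compounds shown, and "the series" means these compounds.

Measured compounds:
- compound 1, `CCCCCCCCCCOc1cccc(OCCCCCC(=O)N(Cc2ccc(C(=O)OC)cc2)c2ccc(C(=O)OC)cc2)c1`: 78%
- compound 2, `CCCCCCCCCCOc1cc(OCCCCCCCCCC)cc(OCCCCCC(=O)N(c2cccc(C(=O)O)c2)c2cccc(C(=O)O)c2)c1`: 20%

Going by the values given here, in an assay on isolated protein for binding affinity to P-selectin (Homo sapiens), read by ELISA, tested at 500 uM (on this read-out lower numbers stand for less inhibition and higher numbers for more inhibition at the one concentration tested (going by the name of the read-out)), compound 1 gives 78%, the higher of the two numbers known. Compound 2 gives 20% in this assay, a number far enough below compound 1 to lie beyond the usual scatter. Compound 2 differs from compound 1 in several places at once, so those two values alone say nothing about any single change.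

Compound 3, `CCCCCCCCCCOc1cccc(OCCCCCC(=O)N(Cc2ccc(C(=O)OC)cc2)c2cccc(C(=O)OC)c2)c1`, has not yet been measured in this assay. It keeps every atom of compound 1 but joins them differently: 3-(methoxycarbonyl)phenyl in place of 4-(methoxycarbonyl)phenyl on an amide-type nitrogen. The only difference is where the methoxycarbonyl group sits on one of the two aryl groups carried by the amide-type nitrogen.

Among the compounds with values here, no step between measured compounds shows what this change does on its own. Compound 3 is expected to give a somewhat lower number than compound 1, the step from a number 13 percentage points lower from compound 1 to compound 3 (beyond the scatter) being a modest drop that may not exceed the scatter. The estimate for compound 3 in this assay is 65%, with a range from 40% to 85%.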

Compound 3, a percentage reported as inhibition, at one concentration (the size of the read-out at that concentration, not a potency): 79%
The estimate for compound 3 lay 14 percentage points below the measured number, and the stated range covers the measured number.
By their numbers in this assay, from the lowest: compound 2; then compounds 1 and 3 (each within the scatter of the next).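

In this assay, putting 3-(methoxycarbonyl)phenyl in place of 4-(methoxycarbonyl)phenyl on the amide-type nitrogen gives a number 1 percentage points higher from compound 1 to compound 3 (within the scatter), so the read-out does not separate compound 1 from compound 3. Going by these compounds alone, this is the first comparison that changes only one place, and it shows that, at the one concentration tested, the read-out does not register where the methoxycarbonyl group sits on this aryl group, at least for these two arrangements. Nothing measured here explains this result, and no information on how these compounds bind is available to interpret it.

Still open, as far as these compounds go, is what a carboxylic acid or an amine in place of this methoxycarbonyl group would do; compound 2 carries carboxylic acids, but it differs from compound 1 in several places at once, so it cannot answer that question. Also open, from the compounds shown here alone, are whether moving the other methoxycarbonyl group in the molecule would leave the number as unchanged, and whether compound 1 and compound 3 would stay together at other concentrations.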